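Benzyl Substitution on a Triazole-Linked Chromone Scaffold

The compounds below may be only part of what the source reports. "The series", "measured", "known", "first", "only" and "open" are said of these compounds alone.

Measured compounds:
Compound 1 `O=c1ccoc2cc(OCc3cn(Cc4ccccc4)nn3)ccc12`, > 100000 nM
Compound 2 `O=c1ccoc2cc(OCc3cn(Cc4cccc([N+](=O)[O-])c4)nn3)ccc12`, > 100000 nM

Compound 1 `O=c1ccoc2cc(OCc3cn(Cc4ccccc4)nn3)ccc12` carries an unsubstituted benzyl group on the triazole. In a functional assay on MDA-MB-231 cells (Homo sapiens) for cytotoxicity, read by MTT assay, with a stated time of 48 h (a higher number here means a weaker inhibitor, a lower number a stronger inhibitor), compound 1 gives only a limit, > 100000 nM, not a number. Compound 2 `O=c1ccoc2cc(OCc3cn(Cc4cccc([N+](=O)[O-])c4)nn3)ccc12` carries a nitro in place of hydrogen on an aromatic carbon of that benzyl group. In this assay compound 2 likewise gives only a limit, > 100000 nM. The step that the two limits leave unreadable from compound 1 to compound 2 therefore cannot be sized. Compound 2 stands at the limit of > 100000 nM in this assay, at which 2 of the 2 values shown sit, together with compound 1.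

Compound 3 `COc1ccc(Cn2cc(COc3ccc4c(=O)ccoc4c3)nn2)cc1` differs from compound 2 as follows:
4-methoxyphenyl in place of 3-nitrophenyl on a saturated chain carbon bound to an aromatic nitrogen

Going by the values given here, the only measured step bears on compound 3 merely by showing that a change on the same benzyl ring, from compound 1 to compound 2, left both values at the limit. Among the compounds with values here, no measured step gives a readable size, so the step that the limit leaves unreadable from compound 2 to compound 3 from compound 2 to compound 3 is expected to be of no readable direction. Compound 3 is therefore estimated to give 150000 nM in this assay, within 40000 nM to 600000 nM, most probably again as a limit rather than a number.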

Compound 3, half-maximal inhibitory concentration: > 100000 nM
Compound 3: no number, only a limit; the forecaster's own chance of this, stated with the estimate: 75%; the middle value lies beyond the limit too.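

In this assay compound 3 gives only a limit, > 100000 nM, not a number. Going by these compounds alone, no step from compound 1 or compound 2 to compound 3 can therefore be read, and the three compounds share one position: the limit of > 100000 nM in this assay, at which 3 of the 3 values shown sit. The compounds shown leave open whether any change on the benzyl group would give a readable value in this assay.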